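Ring Swap on the Thiocarbonyl: Compound 3 to Compound 4

The source may report more compounds than this note shows. Statements on the series, on what has been measured and on what is new or still open speak of the compounds shown alone.

Compound 1 `N/C(=N\NC(=S)N1CCOCC1)c1ccccn1` — 44.5%
Compound 2 `N/C(=N\NC(=S)N1CCCC1)c1ccc(F)cn1` — 52.6%
Compound 3 `Cc1cccc(/C(N)=N/NC(=S)N2CCOCC2)n1` — 21.6%

These three compounds were examined in a functional assay on MCF7 cells (Homo sapiens) for cytotoxicity, read by MTT assay, with a stated time of 72 h, tested at 3 uM; a higher number here means more inhibition of growth at the concentration tested, a lower number less inhibition of growth. Compound 3 stands lowest of the three: compound 1 lies nearest to it, compound 2 furthest. Among the measured compounds shown here, the only single-point step among the measured compounds is a number 22.9 percentage points lower from compound 1 to compound 3 (beyond the scatter), a modest drop that sets compound 3 apart from compound 1.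

Compound 4 `Cc1cccc(/C(N)=N/NC(=S)N2CCCC2)n1` has not been measured. It differs from compound 3 by pyrrolidin-1-yl in place of morpholin-4-yl on a thiocarbonyl carbon. For the measured compounds named here, no measured pair isolates this change. Compounds 1 and 2 carry the two rings in question, but they also differ on the aromatic ring, and their values in this assay lie within the scatter of each other, so they show no effect that can be attributed to the ring swap alone. On this basis no step beyond the scatter is expected. Compound 4 is therefore estimated to give 26% in this assay, in a range from 10% to 45%, a step of a number 4.4 percentage points higher from compound 3 to compound 4 (within the scatter) being expected.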

Compound 4, percent growth inhibition at one concentration: 26.6%
Beside the measured number, compound 4's estimate is 0.6 percentage points below it; low and high end bracket the measured number.
By their numbers in this assay, from the lowest: compounds 3 and 4 (each within the scatter of the next); then compounds 1 and 2 (each within the scatter of the next).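

Among the compounds shown here, with a number 5 percentage points higher from compound 3 to compound 4 (within the scatter) in this assay, pyrrolidin-1-yl in place of morpholin-4-yl on a thiocarbonyl carbon is isolated in a single pair for the first time, and on the core of compound 3 the two rings read alike within the scatter. In this pair, the thiocarbonyl position therefore tolerates the smaller ring, which has no oxygen and no hydrogen-bond acceptor, without a step beyond the scatter. No outside measurement bears on this result.

As far as these compounds go, it remains open whether the two rings would also read alike on the cores of compound 1 and compound 2. From the compounds shown here alone, it also remains open how a piperidin-1-yl ring, a piperazin-1-yl ring or an open-chain dimethylamino group would read on the same thiocarbonyl carbon.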